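Acyl variation at the ring nitrogen: phenyl replaces cyclopropyl

The source may report more compounds than this note shows. Statements on the series, on what has been measured and on what is new or still open speak of the compounds shown alone.

Compound 3 `COc1ccc(N)c(C2=NN(C(=O)C3CC3)CC2)c1` gives 19.9% in an assay on isolated protein for inhibition of Nitric oxide synthase, inducible (Homo sapiens), with a stated time of 30 min, tested at 1 mM; on this read-out lower numbers stand for less inhibition and higher numbers for more inhibition at the one concentration tested (going by the name of the read-out). It stands second highest of the three measured compounds; its nearest neighbour is compound 1 `COc1ccc(N)c(C2=NN(C(C)=O)CC2)c1` with 20.4%, a gap within the scatter, and its furthest is compound 2 `CCCCC(=O)N1CCC(c2cc(OC)ccc2N)=N1` with 0.18%, a gap beyond the scatter. Compound 4 `COc1ccc(N)c(C2=NN(C(=O)c3ccccc3)CC2)c1` differs from compound 3 by phenyl in place of cyclopropyl on a carbonyl carbon.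

Within the data shown here, two measured steps bear on this change at the carbonyl carbon. Going from the smallest group to butyl, a number 20.2 percentage points lower from compound 1 to compound 2 (beyond the scatter); returning from butyl to cyclopropyl, a number 19.7 percentage points higher from compound 2 to compound 3 (beyond the scatter). Within these three compounds, the larger group on the carbonyl carbon went with lower inhibition. Phenyl brings six heavy atoms where cyclopropyl brought three, so a modest decrease is expected in this assay, a number 11.9 percentage points lower from compound 3 to compound 4 (beyond the scatter), though the data hold no aromatic group at this position and the step could also fall within the scatter. Compound 4 is therefore estimated at 8%, with a range from 0% to 22%.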

Compound 4, a percentage reported as inhibition, at one concentration (the size of the read-out at that concentration, not a potency): 12.2%
Compound 4: middle estimate off by 4.2 percentage points, on the low side, within the range that was stated.
By their numbers in this assay, from the lowest: compound 2; then compounds 4, 3 and 1 (each within the scatter of the next).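

In this assay, among these compounds, phenyl on the carbonyl carbon gives the first aromatic group at this position, and it does not separate compound 4 from the compounds with smaller groups: the steps are a number 7.7 percentage points lower from compound 3 to compound 4 (within the scatter) and a number 8.2 percentage points lower from compound 1 to compound 4 (within the scatter) on this read-out. Butyl alone stands apart, with a number 12 percentage points higher from compound 2 to compound 4 (beyond the scatter) in the reverse direction, so the earlier link between a larger group and lower inhibition now rests on compound 2, and compound 4, with its six heavy atoms in the entering group, goes against it. No evidence bears on why butyl and phenyl differ here.

Still open, going by these compounds, is how a phenyl carrying an amine or a carboxylic acid, or a chain longer than butyl, would read in this assay at this position. All four readings come from a single concentration, and none of them gives a potency.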